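The source may report more compounds than this note shows. Statements on the series, on what has been measured and on what is new or still open speak of the compounds shown alone.

Compound 1 `O=C(/C=C/c1ccc(O)c(CN2CCCCC2)c1)c1ccc(C(F)(F)F)cc1` gives 8220 nM
Compound 2 `O=C(/C=C/c1ccc(CN2CCCCC2)c(O)c1)c1ccc(Br)cc1` gives 7270 nM
Compound 3 `O=C(CCc1ccc(CN2CCCCC2)c(O)c1)c1cccs1` gives 168000 nM

These numbers come from an ADME assay on CHO cells (Cricetulus griseus) for cytotoxicity, read by MTT assay; a higher number here means a weaker inhibitor, a lower number a stronger inhibitor. Compound 3 has the highest of the three, beyond the scatter from both compound 1 and compound 2.

Compound 4 `Oc1cc(CCCc2ccccc2)ccc1CN1CCCCC1` has not been measured yet. It carries benzyl in place of (thiophen-2-yl)carbonyl on a saturated chain carbon, two bonds along the chain from an aromatic carbon. Within the data shown here, no measured pair shows this change, so any expectation is loose. With compound 3 at 168000 nM so far above the others, a lower number seems likelier than a higher one. A moderate move is expected (a 3.4-fold lower number from compound 3 to compound 4 (0.53 log units; beyond the scatter)), clearly beyond the scatter. In this assay the estimated value for compound 4 is 50000 nM (range 14000 nM to 170000 nM).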

Compound 4, half-maximal inhibitory concentration: 162000 nM
Compound 4: middle estimate off by 3.2-fold (0.51 log units), on the low side; measured number inside the range.
By their numbers in this assay, from the lowest: compounds 2 and 1 (each within the scatter of the next); then compounds 4 and 3 (each within the scatter of the next).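

In this assay, putting benzyl in place of (thiophen-2-yl)carbonyl on a saturated chain carbon gives a 1.0-fold lower number from compound 3 to compound 4 (0.02 log units; within the scatter), so the two groups cannot be told apart at this position. The swap removes the carbonyl and the five-membered aromatic ring together, yet the reading stays level. Nothing available explains this match.

On these data alone, because both features change at once, the effect of each alone remains unknown. Also open, as far as these compounds go, is whether an amine or a carboxylic acid at this position would give a different number.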